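Working notes: amide-nitrogen variants and a naphthyl extension

The source may hold more compounds than are shown below. What is called first, only, known or untested is meant among the compounds shown, and "the series" means these compounds.

Compound 1 `CC(=O)Oc1cccc(N2C(=O)/C(=C/N3N=C(c4ccccc4)CC3c3ccccc3O)SC2=S)c1` in a functional assay on SK-OV-3 cells (Homo sapiens) for antiproliferative activity, read by MTT assay, with a stated time of 72 h (a higher number here means a weaker inhibitor, a lower number a stronger inhibitor), gives > 10000 nM, which is a limit of the assay rather than a number.
Compound 2 `CC(=O)Oc1ccc(N2C(=O)/C(=C/N3N=C(c4ccccc4)CC3c3ccccc3O)SC2=S)cc1` in this assay gives 244 nM.
Compound 3 `CCOC(=O)CCN1C(=O)/C(=C/N2N=C(c3ccccc3)CC2c2ccccc2O)SC1=S` in this assay gives > 10000 nM, again a limit of the assay.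

For the measured compounds named here, compound 2 holds the only number in this set; the other two values are limits, both sitting at the limit of > 10000 nM in this assay, at which 2 of the 3 values shown sit. The step of an at least 40-fold lower number from compound 1 to compound 2 (1.61 log units; beyond the scatter) and the step of an at least 40-fold higher number from compound 2 to compound 3 (1.61 log units; beyond the scatter) are both large, while a step that the two limits leave unreadable from compound 1 to compound 3 cannot be read because both ends are limits. All three measured steps change the group on the amide-type nitrogen in the ring and leave the rest of the shared core untouched.

Compound 4 `CC(=O)Oc1ccc(N2C(=O)/C(=C/N3N=C(c4ccc5ccccc5c4)CC3c3ccccc3O)SC2=S)cc1` differs from compound 2 by naphthalen-2-yl in place of phenyl on a carbon with a double bond to nitrogen. Going by the values given here, no measured step touches this carbon; the measured changes all concern the amide-type nitrogen and so give no direct guide to the size of this step in this assay. With nothing to argue for a large move in either direction, the expectation for compound 4 is a step within the scatter, a 1.2-fold higher number from compound 2 to compound 4 (0.09 log units; within the scatter). Compound 4 is therefore estimated at 300 nM, with a range from 80 nM to 1500 nM that leaves room for a moderate shift either way.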

Compound 4, half-maximal inhibitory concentration: > 10000 nM
Compound 4 ended at the assay's limit (the forecaster's own chance of this, stated with the estimate: 15%); at least 33-fold (1.52 log units) between middle value and limit.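

For the compounds shown here, the carbon with a double bond to nitrogen, untouched by the earlier steps, proves just as able to move the read-out in this assay: naphthalen-2-yl in place of phenyl gives an at least 40-fold higher number from compound 2 to compound 4 (1.61 log units; beyond the scatter). The number held by compound 2 therefore depends on more than the group on the amide-type nitrogen, as this change keeps the 4-acetoxyphenyl group in place and the number is still lost. The value of compound 4 is a limit of the assay, shared with the other compounds there: the limit of > 10000 nM in this assay, at which 3 of the 4 values shown sit.

Going by these compounds, whether a 4-chlorophenyl group or a pyridyl ring on this carbon would keep a number close to that of compound 2 stays open. How far compound 4 lies past the limit also cannot be read.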